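The source may hold more compounds than are shown below. What is called first, only, known or untested is meant among the compounds shown, and "the series" means these compounds.

Measured so far in a functional assay on HCT-116 cells (Homo sapiens) for antiproliferative activity, read by MTT assay, with a stated time of 72 h; on this read-out higher numbers stand for weaker inhibition and lower numbers for stronger inhibition:
compound 1 `CC(C)N1C(=O)COc2ccc(-c3cnc(Cl)c(NS(=O)(=O)c4ccc(F)cc4)c3)cc21` gives 18900 nM
compound 2 `COc1cccc(N2C(=O)COc3ccc(-c4cnc5ccccc5c4)cc32)c1` gives 8240 nM
compound 3 `Cc1ccc(N2C(=O)COc3ccc(-c4cnc(Cl)c(NS(=O)(=O)c5ccc(F)cc5)c4)cc32)cc1` gives 34300 nM

Compound 2 holds the lowest of the three numbers, with compound 1 and compound 3 both beyond the scatter above it. Next is compound 4 `O=C1COc2ccc(-c3cnc4ccccc4c3)cc2N1c1ccc(F)cc1`, with 4-fluorophenyl in place of 3-methoxyphenyl on an amide-type nitrogen in a ring. Among the measured compounds shown here, only one measured step changes the group on that nitrogen (a 1.8-fold higher number from compound 1 to compound 3 (0.26 log units; within the scatter)). For the measured compounds named here, it lies within the scatter and sits on a different core, and no measured step compares these two groups directly. No step beyond the scatter is therefore expected in this assay, and the expected step is small (a 1.1-fold higher number from compound 2 to compound 4 (0.04 log units; within the scatter)). The estimated value for compound 4 is 9000 nM (expected range 3500 nM to 25000 nM).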

Compound 4, half-maximal inhibitory concentration: > 40000 nM
Compound 4 gave a limit, no number (the forecaster's own chance of this, stated with the estimate: 8%); middle value at least 4.4-fold (0.64 log units) away from the limit.
By their numbers in this assay, from the lowest: compound 2; then compounds 1 and 3 (each within the scatter of the next). At a limit, above all of these: compound 4.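

On the amide-type nitrogen in a ring, the choice of aryl group registers in this assay: 4-fluorophenyl in place of 3-methoxyphenyl gives an at least 4.8-fold higher number from compound 2 to compound 4 (0.68 log units; beyond the scatter). The earlier step at this position, on a different core, was a 1.8-fold higher number from compound 1 to compound 3 (0.26 log units; within the scatter), so this nitrogen is not insensitive to change across the series. Compound 4 gives a limit of the assay, not a number: the limit of > 40000 nM in this assay, at which 1 of the 4 values shown sits.

On these data alone, the full size of the step therefore stays open. Also open, as far as these compounds go, is how an aminomethyl or carboxylic acid group on that phenyl ring, or a longer alkyl chain in its place, would read on the core of compound 2.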